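The source may hold more compounds than are shown below. What is called first, only, known or untested is meant among the compounds shown, and "the series" means these compounds.

Compound 3 `O=CN1CCN(c2ccc(Cl)cc2)C1=S` was tested in a functional assay on NCI-H23 cells (Homo sapiens) for inhibition, read by sulforhodamine B assay, with a stated time of 48 h (on this read-out lower numbers stand for stronger inhibition of growth and higher numbers for weaker inhibition of growth), where compound 3 gives 23000 nM. For comparison, compound 1 `N#C/C(=C\N1CCN(C(=O)c2ccco2)C1=S)C(=O)Nc1ccc(Cl)cc1` gives 12300 nM and compound 2 `N#C/C(=C\N1CCN(C(=O)c2ccco2)C1=S)C(N)=O` gives 21400 nM; all three numbers lie within the usual scatter of one another, so none can be called stronger or weaker. For the measured compounds named here, the only single-point step among them is a 1.7-fold higher number from compound 1 to compound 2 (0.24 log units; within the scatter), a change at an amide-type nitrogen. Compound 4 `O=CN1CCN(c2ccc(Cl)c(Cl)c2)C1=S` differs from compound 3 by chloro in place of hydrogen on an aromatic carbon. Going by the values given here, no measured step adds a chloro to an aromatic ring, so the one measured step bears on it only loosely, and it stayed within the scatter. For compound 4 the expected step is therefore a 1.2-fold lower number from compound 3 to compound 4 (0.06 log units; within the scatter), none beyond the scatter. Compound 4 is estimated at 20000 nM, within a range from 8000 nM to 50000 nM.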

Compound 4, concentration for 50% growth inhibition: 20900 nM
Estimate against measurement, compound 4: 1.0-fold (0.02 log units) below, within the range that was stated.
By their numbers in this assay, from the lowest: compounds 1, 4, 2 and 3 (each within the scatter of the next).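

Placing a chloro on this aromatic carbon, ortho to a chloro group and meta to a group of 8 heavy atoms, gives a 1.1-fold lower number from compound 3 to compound 4 (0.04 log units; within the scatter) in this assay. For the compounds shown here, this is the first direct reading of a chloro added to an aromatic ring in this set, and compound 3 and compound 4 cannot be told apart. No measured evidence is available to explain this result.

The compounds shown leave open whether an amine, a methoxy group or a carboxylic acid on this same carbon would separate from hydrogen and chloro. They also leave open whether a second chloro would give a similar reading on the chlorinated ring of compound 1.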